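The compounds below may be only part of what the source reports. "The series", "measured", "known", "first", "only" and "open" are said of these compounds alone.

In a functional assay on the whole organism with Rattus norvegicus as the target (a lower number here means that less compound is needed, a higher number that more compound is needed for the effect), compound 1 `COc1ccccc1N1CCN(Cc2ccc(-c3ccccc3)[nH]2)CC1` gives 13 mg/kg and so has the lowest number of the set, with compound 3 `COc1ccccc1N1CCN(Cc2ccc(-c3c(F)cccc3F)[nH]2)CC1` closest at 30 mg/kg on that scale. Compound 2 `COc1ccccc1N1CCN(Cc2ccc(-c3cccc(Cl)c3)[nH]2)CC1` shows > 100 mg/kg as a limit of the assay. Compound 4 `COc1ccccc1N1CCN(Cc2ccc(-c3ccccc3)n2-c2ccccc2)CC1` differs from compound 1 by phenyl in place of hydrogen on an aromatic nitrogen. Going by the values given here, no measured step tests that place. Among the compounds with values here, the only guides are changes to the other phenyl group: one is an at least 7.6-fold higher number from compound 1 to compound 2 (0.88 log units; beyond the scatter) and the other is a 2.3-fold higher number from compound 1 to compound 3 (0.36 log units; beyond the scatter) with the number rising both times. A modest rise is therefore expected in this assay and the expected step is a 2.7-fold higher number from compound 1 to compound 4 (0.43 log units; beyond the scatter) on this reasoning. For compound 4 the estimated value is 35 mg/kg with an expected range (10 mg/kg to 120 mg/kg).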

Compound 4, dose for half-maximal effect: > 100 mg/kg
Compound 4 was reported as a limit; the forecaster's own chance of this, stated with the estimate: 30%; at least 2.8-fold (0.45 log units) between middle value and limit.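

In this assay, going by these compounds alone, the aromatic nitrogen is tested here for the first time, and phenyl in place of its hydrogen gives an at least 7.6-fold higher number from compound 1 to compound 4 (0.88 log units; beyond the scatter). Within the data shown here, the earlier compounds changed only the other phenyl group, so this is the first evidence that the number also rises with a change at this position. The value of compound 4 is a limit, so the step has a known minimum but no known size: the limit of > 100 mg/kg in this assay, at which 2 of the 4 values shown sit. Going by these compounds, whether a methyl group on this nitrogen would keep the number of compound 1 remains open, as does the effect of a benzyl group there.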